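The source may hold more compounds than are shown below. What is called first, only, known or untested is meant among the compounds shown, and "the series" means these compounds.

Measured compounds:
Compound 1 `Cc1ccc(C)c(C(=O)OC(CCN(C)C)c2ccc(Cl)cc2)c1` — 86%
Compound 2 `Cc1ccc(C(=O)OC(CCN(C)C)c2ccc(Cl)cc2)cc1` — 56%

Among the measured compounds shown here, in an assay on NIH3T3 cells with Urotensin-2 receptor (Homo sapiens) as the target (a lower number here means a smaller maximal response, a higher number a larger maximal response), compound 2 holds the lowest of the two numbers, with compound 1 as its only neighbour. For the measured compounds named here, the one measured step, a number 30 percentage points lower from compound 1 to compound 2 (beyond the scatter), changed the aryl group on the carbonyl carbon, as does the step to compound 3 `Cc1cc(Br)ccc1C(=O)OC(CCN(C)C)c1ccc(Cl)cc1`, where (4-bromo-2-methylphenyl in place of 4-methylphenyl on a carbonyl carbon). Going by the values given here, since compound 3 again carries a disubstituted ring, a modest rise back toward compound 1 is expected, though no measured step covers bromine. Compound 3 is therefore estimated at 70% (range 50% to 90%), an expected step of a number 14 percentage points higher from compound 2 to compound 3 (beyond the scatter).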

Compound 3, largest response reached (reported as efficacy), in percent of the reference or control that the assay uses: 95%
Compound 3: middle estimate off by 25 percentage points, on the low side; the whole stated range lies below it.
By their numbers in this assay, from the lowest: compound 2; then compounds 1 and 3 (each within the scatter of the next).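

In this assay, 4-bromo-2-methylphenyl in place of 4-methylphenyl on the carbonyl carbon gave a number 39 percentage points higher from compound 2 to compound 3 (beyond the scatter) and so restored the response lost with 4-methylphenyl. Set against 2,5-dimethylphenyl, the same group gave a number 9 percentage points higher from compound 1 to compound 3 (within the scatter) and the two differently substituted rings therefore stand level, both apart from 4-methylphenyl. No evidence on the cause of these steps is available. Going by these compounds, whether the bromine or the methyl group of 4-bromo-2-methylphenyl carries the step stays open, as does what an amine or a methoxy group on that ring would give.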